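Ether ring changes on the shared core

A few compounds are considered here, and "the series" means these few. Any claim that something is new, unique, unknown or untested is made for them only; others in the source may bear on it.

Compound 1 `CC(=O)N1CCCn2nc(COc3cccc(F)c3)cc21` gives 58% in a functional assay on HEK293 cells for positive allosteric modulation of metabotropic glutamate receptor 5 (Homo sapiens), read by calcium flux (a higher number here means a larger maximal response, a lower number a smaller maximal response), the second highest of the three numbers measured. Compound 2 `CC(=O)N1CCCn2nc(COc3cc(F)cc(F)c3)cc21` gives 63%, and compound 3 `CC(=O)N1CCCn2nc(COc3cc(F)cc(C#N)c3)cc21` gives 39%. The step of a number 5 percentage points higher from compound 1 to compound 2 (within the scatter) stays within the scatter, whereas a number 19 percentage points lower from compound 1 to compound 3 (beyond the scatter) and a number 24 percentage points lower from compound 2 to compound 3 (beyond the scatter) are modest but beyond it. Compound 4 `CC(=O)N1CCCn2nc(COc3ccncc3)cc21` differs from compound 1 by pyridin-4-yl in place of 3-fluorophenyl on an oxygen on a saturated carbon. For the measured compounds named here, no measured step exchanges the whole ring attached to the oxygen, so none bears on this change directly; the nearest comparison is cyano in place of hydrogen on an aromatic carbon, which gave a number 19 percentage points lower from compound 1 to compound 3 (beyond the scatter). For compound 4 a modest fall is therefore expected, a number 11 percentage points lower from compound 1 to compound 4 (beyond the scatter). Compound 4 is estimated at 47%, with a range from 30% to 66%.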

Compound 4, largest response reached (reported as percent of maximum), in percent of the reference or control that the assay uses: < 15%
Compound 4: a limit, no number; the forecaster's own chance of this, stated with the estimate: 0%; at least 32 percentage points between middle value and limit.
By their numbers in this assay, from the lowest: compound 3; then compounds 1 and 2 (each within the scatter of the next). At a limit, below all of these: compound 4.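

Pyridin-4-yl in place of 3-fluorophenyl on an oxygen on a saturated carbon gives a number at least 43 percentage points lower from compound 1 to compound 4 (beyond the scatter) in this assay, a large step, where the cyano step, a number 19 percentage points lower from compound 1 to compound 3 (beyond the scatter), was modest. The result for compound 4 is a limit, not a number: the limit of < 15% in this assay, at which 1 of the 4 values shown sits. Of the rings shown on the oxygen, the three phenyl rings keep a measurable response, and the one ring with a hetero atom gives only this limit.

Compound 4 loses the fluoro and gains the ring nitrogen in one step, so the two changes stay unseparated. An unsubstituted phenyl ring or a fluoro-bearing pyridine ring at this oxygen would separate them.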